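Methyl in place of methoxy at compound 3

A few compounds are considered here, and "the series" means these few. Any claim that something is new, unique, unknown or untested is made for them only; others in the source may bear on it.

Measured in a functional assay on NCI-H460 cells (Homo sapiens) for cytotoxicity, read by MTT assay, with a stated time of 68 h; a lower number here means a stronger inhibitor, a higher number a weaker inhibitor:
- Compound 1 `COc1ccc(-c2cc(NC(=O)C(Cl)Cl)cc(-c3ccc(OC)cc3)c2)cc1` gives > 30000 nM, which is a limit
- Compound 2 `O=C(Nc1cccc(-c2ccccc2C(F)(F)F)c1)C(Cl)Cl` gives 7550 nM
- Compound 3 `COc1ccc(-c2cccc(NC(=O)C(Cl)Cl)c2)cc1` gives 43300 nM

The value for compound 1 is a limit and not a number. Of the two actual numbers, compound 3 has the higher at 43300 nM, which makes it the weaker inhibitor, and compound 2 stands lower at 7550 nM, a gap beyond the scatter.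

Compound 4 `Cc1ccc(-c2cccc(NC(=O)C(Cl)Cl)c2)cc1` has methyl in place of methoxy on an aromatic carbon, para to a large group (methyl in place of methoxy on an aromatic carbon). For the measured compounds named here, the one measured step is a step that the limit leaves unreadable from compound 1 to compound 3, so it offers no size to carry over, and no measured step exchanges methoxy for methyl. With nothing to suggest a shift, no change beyond the scatter is expected in this assay. The expected step is a 1.2-fold lower number from compound 3 to compound 4 (0.09 log units; within the scatter). For compound 4 the estimate is 35000 nM, with an expected range from 15000 nM to 80000 nM.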

Compound 4, half-maximal inhibitory concentration: 8000 nM
For compound 4 the middle estimate is 4.4-fold (0.64 log units) above the measured one; measured number below the stated range.
By their numbers in this assay, from the lowest: compounds 2 and 4 (each within the scatter of the next); then compound 3.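

In this assay, methyl in place of methoxy on this aromatic carbon gives a 5.4-fold lower number from compound 3 to compound 4 (0.73 log units; beyond the scatter), the first step among these compounds that can be read with a size. The position, para to a large group, therefore responds to what it carries: exchanging methoxy for methyl, with one heavy atom and the one hydrogen-bond acceptor fewer, moves the number beyond the scatter. Nothing measured here says which difference between the two groups accounts for the step.

Going by these compounds, how a hydroxyl, a chlorine, an ethyl chain or an amine would fare at this position stays open. Also open, on these data alone, is whether the same exchange would carry over to the core of compound 1, whose value is a limit and not a number.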